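Bromo to Nitro on a Compound Already at the Limit

This account rests on a few compounds, and the source may have more. Where it says the series, first, only, none or still open, it means among the compounds named here.

Three compounds have so far been run in a functional assay on CRL2813 cells (Homo sapiens) for cytotoxicity, read by sulforhodamine B assay, with a stated time of 5 days; on this read-out higher numbers stand for weaker inhibition and lower numbers for stronger inhibition. Compound 1 `O=C(Nc1cccc(C(F)(F)F)c1)N[C@H]1CC[C@H](O)CC1` reached only the limit of this assay, giving > 20000 nM. Compound 2 `O=C(Nc1ccc(Br)cc1)N[C@H]1CC[C@H](Oc2ccc(F)cc2)CC1` likewise gave only a limit, > 20000 nM. Going by the values given here, compound 3 `O=C(Nc1cccc(C(F)(F)F)c1)N[C@H]1CC[C@@H](Oc2ccc(F)cc2)CC1` is the one that returned a number, 2600 nM, but it differs from compound 2 in more than one place, so no single step connects the two. Compound 2 therefore stands at the limit of > 20000 nM in this assay, at which 2 of the 3 values shown sit, with no measured number to say how far beyond that limit it really lies.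

Compound 4 `O=C(Nc1ccc([N+](=O)[O-])cc1)N[C@H]1CC[C@H](Oc2ccc(F)cc2)CC1` is the next compound to be measured. It differs from compound 2 by nitro in place of bromo on an aromatic carbon. Among the compounds with values here, no measured pair in this set shows what such a swap does in this assay, so there is no basis for expecting a shift beyond the usual scatter in either direction; the starting point is itself a limit. Compound 4 is therefore expected to stay close to that limit, around 25000 nM, within 8000 nM to 60000 nM. The step from compound 2 to compound 4 is estimated as a step that the limit leaves unreadable from compound 2 to compound 4, which amounts to no real movement.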

Compound 4, half-maximal inhibitory concentration: 2300 nM
Compound 4: the middle estimate sits 11-fold (1.04 log units) above what was measured, outside the stated range (below it).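

In this assay, going by these compounds alone, nitro in place of bromo on the six-membered aromatic ring, para to a large group, gives an at least 8.6-fold lower number from compound 2 to compound 4 (0.93 log units; beyond the scatter), the first change in a single place in this set and one that lies beyond the usual scatter. Everything else in the two molecules is the same, so this one position on its own is enough to turn a compound that stays at the limit into one that returns a real number. The full size of the step still cannot be read, because compound 2 gives only a limit and so fixes just the smallest possible shift: the limit of > 20000 nM in this assay, at which 2 of the 4 values shown sit.

Only bromo and nitro are shown on this carbon, so it remains unclear whether the gain belongs to nitro in particular or would also come with other replacements for bromo, such as a nitrile, an amine or a carboxylic acid. One pair also cannot say whether the same swap would have a similar effect on a different version of the shared core, or whether nitro would do the same from another carbon of that ring.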